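Methyl on the ring nitrogen: growth inhibition notes

The source may report more compounds than this note shows. Statements on the series, on what has been measured and on what is new or still open speak of the compounds shown alone.

Measured so far:
compound 1 `Nc1nc(N)c2c(n1)NC(=O)C(c1c(Cl)cccc1Cl)C2`: > 100000 nM
compound 2 `Nc1nc(Nc2ccccc2)nc2[nH]c(=O)c(-c3c(Cl)cccc3Cl)cc12`: > 100000 nM

In a functional assay on HBL2 cells (Homo sapiens) for inhibition, read by MTT assay, with a stated time of 48 h (on this read-out higher numbers stand for weaker inhibition of growth and lower numbers for stronger inhibition of growth), compound 1 gives > 100000 nM, which is a limit of the assay and not a number. Compound 2 likewise gives > 100000 nM in this assay, again a limit rather than a measured value. On the numbers shown, compound 2 stands at the limit of > 100000 nM in this assay, at which 2 of the 2 values shown sit, so no order can be drawn between compound 1 and compound 2, and no step between measured compounds is available.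

Compound 3 `Cn1c(=O)c(-c2c(Cl)cccc2Cl)cc2c(N)nc(Nc3ccccc3)nc21` is the next candidate for this assay. It differs from compound 2 by methyl in place of hydrogen on an aromatic nitrogen. Going by the values given here, nothing in the two measured values gives direction for this change; the only anchor is that compound 2 sits at a limit. The expected step of a number no higher from compound 2 to compound 3 (the limit leaves the size open) is therefore taken as none beyond the scatter, with a real chance that compound 3 also returns only a limit. Compound 3 is expected at 100000 nM, with a range from 20000 nM to 300000 nM.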

Compound 3, concentration for 50% growth inhibition: 400 nM
Beside the measured number, compound 3's estimate is 250-fold (2.40 log units) above it; the whole stated range lies above it.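

Methyl in place of hydrogen on an aromatic nitrogen gives, in this assay, an at least 250-fold lower number from compound 2 to compound 3 (2.39 log units; beyond the scatter), the first change in the series that can be read at all. Compound 3 at 400 nM holds the first value shown that is a number and not a limit, so this nitrogen is a position where methyl alone separates a compound with a measurable reading from one without. The step is a bound and not a true size, because compound 2 holds only a limit: the limit of > 100000 nM in this assay, at which 2 of the 3 values shown sit.

Going by these compounds, whether this belongs to methyl as such or to any group on this nitrogen stays open, and an ethyl, a longer chain or a chain ending in an amine at the same place would separate the two readings. The whole finding rests on a single pair, the compounds shown give no reason for the step, and compound 1 differs from compound 3 in more than one place, so it adds nothing on this change.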